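The source may hold more compounds than are shown below. What is called first, only, known or untested is meant among the compounds shown, and "the series" means these compounds.

Measured so far in a functional assay on OVCAR-5 cells (Homo sapiens) for inhibition, read by sulforhodamine B assay, with a stated time of 48 h; a higher number here means a weaker inhibitor of growth, a lower number a stronger inhibitor of growth:
Compound 1 `Nc1cc(N)c2nc(-c3ccccc3)c(Oc3ccc(Cl)c(Cl)c3)nc2c1` gives 58900 nM.
Compound 2 `COc1ccc(CNc2nc3cc(N)cc(N)c3nc2-c2ccccc2)cc1OC` gives 41700 nM.
Compound 3 `COc1cc(CNc2nc3cc(N)cc(N)c3nc2-c2ccccc2)cc(OC)c1OC` gives only a limit of the assay, < 50200 nM.

Compound 2 holds the lowest of the two numbers read in this assay; its nearest neighbour, compound 1, sits within the scatter of it, and the third value is a limit. Going by the values given here, the one step that alters a single place, a step that the limit leaves unreadable from compound 2 to compound 3, cannot be read in size because of the limit of < 50200 nM in this assay, at which 1 of the 3 values shown sits.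

Compound 4 `COc1ccc(CNc2nc3cc(N)cc(N)c3nc2-c2ccccc2)cc1` differs from compound 2 by hydrogen in place of methoxy on an aromatic carbon. Among the compounds with values here, no readable measured step touches this place: the only step there, from compound 2 to compound 3, is unreadable. There is therefore no ground for expecting a step in this assay beyond the scatter, in either direction; the expectation rests on compound 2 alone, at 41700 nM. The step is expected to be about a 1.1-fold higher number from compound 2 to compound 4 (0.03 log units; within the scatter). Compound 4 is thus estimated at 45000 nM, with a range from 18000 nM to 110000 nM.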

Compound 4, concentration for total growth inhibition: 45700 nM
Estimate against measurement, compound 4: 1.0-fold (0.01 log units) below; the range from low to high includes it.
By their numbers in this assay, from the lowest: compounds 2, 4 and 1 (each within the scatter of the next).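

In this assay, going by these compounds alone, the change from 3,4-dimethoxyphenyl to 4-methoxyphenyl gives a 1.1-fold higher number from compound 2 to compound 4 (0.04 log units; within the scatter), the first readable step at this place. Hydrogen and methoxy on this aromatic carbon therefore cannot be told apart in this assay, and this one exchange gives no sign that the methoxy group here governs the read-out. Compound 3 still gives only a limit, < 50200 nM, so the one other step at this place cannot be read: the limit of < 50200 nM in this assay, at which 1 of the 4 values shown sits.

As far as these compounds go, whether a hydroxyl group, an amine or a carboxylic acid on this carbon would move the number beyond the scatter remains open. Also open, from the compounds shown here alone, is what happens when the remaining methoxy group of compound 4 is exchanged for hydrogen or for a longer alkoxy chain.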